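Trimming an Ether Side Chain: Compound 3 to Compound 4

The source may report more compounds than this note shows. Statements on the series, on what has been measured and on what is new or still open speak of the compounds shown alone.

Of the compounds shown here, three sharing one core have been tested in a functional assay on DU-145 cells (Homo sapiens) for cytotoxicity, read by MTT assay; a lower number here means a stronger inhibitor, a higher number a weaker inhibitor. Compound 1 `CC(C)=CC[C@@H](OC(=O)c1ccco1)C1=CC(=O)c2c(O)ccc(O)c2C1=O` carries a (furan-2-yl)carbonyl ester on the oxygen of its side chain, and in this assay compound 1 gives > 100000 nM, which is a limit of the assay and not a number. Compound 2 `CCCC(O)CC(=O)O[C@H](CC=C(C)C)C1=CC(=O)c2c(O)ccc(O)c2C1=O` gives > 100000 nM, again only a limit. Among the measured compounds shown here, compound 3 `CCC(O)CO[C@H](CC=C(C)C)C1=CC(=O)c2c(O)ccc(O)c2C1=O`, in which the ester is replaced by a 2-hydroxybutyl ether, is the only compound with a measured number, and it gives 16400 nM. From compound 1 to compound 3 the step is an at least 6.0-fold lower number from compound 1 to compound 3 (0.78 log units; beyond the scatter), and from compound 2 to compound 3 it is an at least 6.0-fold lower number from compound 2 to compound 3 (0.78 log units; beyond the scatter); both rest on the limit of > 100000 nM in this assay, at which 2 of the 3 values shown sit, and so mark only a floor for the gain.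

Compound 4 `CC(C)=CC[C@@H](OCCO)C1=CC(=O)c2c(O)ccc(O)c2C1=O` differs from compound 3 by hydrogen in place of ethyl on a saturated chain carbon bound to an oxygen on a saturated carbon and a saturated chain carbon. Cut one bond further out, the change reads 2-hydroxybutyl to 2-hydroxyethyl. For the measured compounds named here, none of the measured steps touches this part of the chain: both replace an ester with an ether while the chain itself stays, so they give no guide to removing the ethyl. The expected step is therefore about a 1.2-fold higher number from compound 3 to compound 4 (0.09 log units; within the scatter), within the scatter. Compound 4 is estimated at 20000 nM, with a range from 7000 nM to 60000 nM.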

Compound 4, half-maximal inhibitory concentration: 9900 nM
Compound 4: middle estimate off by 2.0-fold (0.31 log units), on the high side; the measured number falls inside the stated range.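

In this assay, among the compounds shown here, this is the first change to the ether chain itself, and taking away the ethyl gives a 1.7-fold lower number from compound 3 to compound 4 (0.22 log units; within the scatter), so the 2-hydroxybutyl and 2-hydroxyethyl chains cannot be told apart in this test. The earlier steps shown here left open whether the ether's advantage over the esters needed the full 2-hydroxybutyl chain, and the shorter chain shows that it did not, with an at least 10-fold lower number from compound 2 to compound 4 (1.00 log units; beyond the scatter) and an at least 10-fold lower number from compound 1 to compound 4 (1.00 log units; beyond the scatter). Those two steps mark only a floor on the size of the gain, since the esters compound 1 and compound 2 give no true number, and the steps are tied to one value that is a limit of the assay and not a number: the limit of > 100000 nM in this assay, at which 2 of the 4 values shown sit.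

Both ethers shown carry a hydroxyl group on their chain, so the compounds leave open whether that group matters, which 2-aminoethyl or plain ethyl in place of 2-hydroxyethyl on the same oxygen would test. They also leave open how a much longer chain, such as 2-hydroxyhexyl, or a chain ending in a carboxylic acid would behave at this position.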